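The source may hold more compounds than are shown below. What is called first, only, known or untested is meant among the compounds shown, and "the series" means these compounds.

For the measured compounds named here, in a functional assay on NCI-H460 cells (Homo sapiens) for inhibition, read by sulforhodamine B assay, with a stated time of 48 h (a lower number here means a stronger inhibitor of growth, a higher number a weaker inhibitor of growth), compound 2 `N#CCC1=NN=C(c2ccc([N+](=O)[O-])cc2)CO1` gives 2 nM and holds the lower of the two numbers so far. Compound 1 `N#CCC1=NN=C(c2ccc([N+](=O)[O-])cc2)C(CC(=O)c2ccc([N+](=O)[O-])cc2)O1` gives 2600 nM in this assay, a gap beyond the scatter. Going by the values given here, with only these two values, the series has no measured step between compounds that differ in one place, and nothing yet shows directly what a single change does here.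

The next compound is compound 3 `N#CCC1=NN=C(c2ccc([N+](=O)[O-])cc2)C(Br)O1`, which has bromo in place of hydrogen on a saturated ring carbon of compound 2 (bromo in place of hydrogen on a saturated ring carbon). The expectation for this assay is a moderate move toward a higher number, beyond the scatter but short of the gap between the two measured compounds. The direction rests on compound 2 at 2 nM being the lower of the two values, while compound 1 at 2600 nM shows how much higher a number can lie in this series. This is weak support, and the range is kept wide. The expected size is a 10-fold higher number from compound 2 to compound 3 (1.00 log units; beyond the scatter) as an estimate. The estimate for compound 3 is 20 nM with an expected range from 3 nM to 300 nM in this read-out.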

Compound 3, concentration for 50% growth inhibition: 8500 nM
The estimate for compound 3 lay 430-fold (2.63 log units) below the measured number; the measured number lies above the stated range.
By their numbers in this assay, from the lowest: compound 2; then compound 1; then compound 3.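

In this assay, bromo in place of hydrogen on a saturated ring carbon gives a 4300-fold higher number from compound 2 to compound 3 (3.63 log units; beyond the scatter), the first measured effect of a single change in this series, and a large one. This ring carbon, next to the ring oxygen, is therefore highly sensitive to substitution: entry of a group of only 1 heavy atom, with no ring and no net charge, is enough to remove most of the growth inhibition seen with compound 2. Nothing available bears on the reason for this loss.

Going by these compounds, it remains open whether the loss is specific to bromo or follows from any replacement of hydrogen at this carbon, a question that fluoro, methyl or hydroxy at the same place would help to settle. On these data alone, it is also open whether other sites are as demanding as this one, which an amine or a carboxylic acid in place of the cyanomethyl group would begin to test.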